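A few compounds are considered here, and "the series" means these few. Any claim that something is new, unique, unknown or untested is made for them only; others in the source may bear on it.

Measured compounds:
- Compound 1 `CC(C)CN(Cc1ccc(N2CCN(CS(C)(=O)=O)CC2)cc1)S(=O)(=O)Cc1ccccc1`: <= 1000 nM (a limit)
- Compound 2 `CC(C)CN(Cc1ccc(N2CCN(C)CC2)cc1)S(=O)(=O)Cc1ccccc1`: 60000 nM
- Compound 3 `CC(=O)N1CCN(c2ccc(CN(C(C)(C)C)S(=O)(=O)Cc3ccccc3)cc2)CC1`: <= 1000 nM (a limit)

In a physicochemical assay for solubility, in phosphate buffer, measured as kinetic solubility, with a stated time of 24 h, at pH 7.4 (on this read-out lower numbers stand for lower solubility and higher numbers for higher solubility), compound 3 gives <= 1000 nM, which is a limit and not a number. It therefore sits at the limit of <= 1000 nM in this assay, at which 2 of the 3 values shown sit.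

Compound 4 `CC(=O)N1CCN(c2ccc(CN(C(C)C)S(=O)(=O)Cc3ccccc3)cc2)CC1` has not yet been measured. It differs from compound 3 by one change, hydrogen in place of methyl on a saturated chain carbon bound to two saturated chain carbons and a sulfonamide nitrogen, so that tert-butyl becomes isopropyl.

Among the compounds with values here, only one measured step is available, an at least 60-fold higher number from compound 1 to compound 2 (1.77 log units; beyond the scatter). It is large, but it puts hydrogen in place of methylsulfonyl on a saturated chain carbon bound to an amine nitrogen in a ring, which is a different change in a different place. It therefore bears on this change only weakly.

Within the data shown here, no measured step covers the change from tert-butyl to isopropyl, so no step beyond the scatter is expected in this assay. The expected step is a number no lower from compound 3 to compound 4 (the limit leaves the size open). Compound 4 is estimated at 1000 nM, with an expected range of 400 nM to 5000 nM. It may well be reported only as a limit.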

Compound 4, solubility: <= 1000 nM
Compound 4: no number, only a limit; the forecaster's own chance of this, stated with the estimate: 65%; the middle value lies on the limit itself.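

In this assay, compound 3 and compound 4 are both reported only as limits, so no step can be read between them. Whether the change from tert-butyl to isopropyl alters the read-out at all stays open, because both compounds sit at the same limit: the limit of <= 1000 nM in this assay, at which 3 of the 4 values shown sit.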